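The compounds below may be only part of what the source reports. "The series", "measured", "known", "first", "only" and "open" are said of these compounds alone.

Measured so far:

compound 1, `CN(Cc1ccc2nccn2c1)c1nnc(-c2ccc(-c3ccccc3F)cc2)o1`, lipophilicity 4.4
compound 2, `Cc1nc(-c2c(C)nn(C)c2C)ccc1-c1nnc(N(C)Cc2ccc3nccn3c2)o1`, lipophilicity 2.5
compound 3, `Cc1cc(-c2c(C)nn(C)c2C)ccc1-c1nnc(N(C)Cc2ccc3ncc(-c4ccccc4)n3c2)o1`, lipophilicity 5.3

In a physicochemical assay for lipophilicity, at pH 7.4 (on this read-out higher numbers stand for higher lipophilicity and lower numbers for lower lipophilicity), compound 3 stands at the top of these three numbers. The nearest to it is compound 1 with 4.4, a gap that lies beyond the scatter of repeated measurements. The furthest away is compound 2 with 2.5, a much wider gap, again beyond the scatter. Within the data shown here, none of these three pairs differs in only one place, so no single-change step between measured compounds is available to guide the next prediction.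

Compound 4, `Cc1cc(-c2c(C)nn(C)c2C)ccc1-c1nnc(N(C)Cc2ccc3ncc(C4CCN(C)CC4)n3c2)o1`, is built from compound 3 by one change: 1-methylpiperidin-4-yl in place of phenyl on an aromatic carbon. Among the measured compounds shown here, the three measured values give no matching single step, so the size of the change has to be judged from the structural change alone. In this assay the expectation is a large downward step, clearly beyond the scatter. The change exchanges a ring of carbon only for a ring with one hetero atom, counted as one hydrogen-bond acceptor. The starting point is compound 3 at 5.3, the highest of the set.

Compound 4 is therefore estimated at 2.8, with a likely range from 2 to 3.6. That estimate means a step of a number 2.50 log units lower from compound 3 to compound 4 (beyond the scatter), expected to fall well outside the usual scatter.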

Compound 4, distribution coefficient: 2.5
Estimate against measurement, compound 4: 0.30 log units above, and the stated range covers the measured number.
By their numbers in this assay, from the lowest: compounds 2 and 4 (each within the scatter of the next); then compound 1; then compound 3.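

In this assay, replacing phenyl with 1-methylpiperidin-4-yl on an aromatic carbon of the five-membered aromatic ring with 2 nitrogen gives a number 2.80 log units lower from compound 3 to compound 4 (beyond the scatter). Among these compounds, this is the first pair that differs in one place, so it shows that the group at this position can move the number a long way on its own, with the rest of the molecule unchanged, which the earlier compounds, differing in several places, could not show. The two groups are close in count, 6 and 7 heavy atoms, and each is a six-membered ring, so a large step can come from an exchange that barely changes the number of heavy atoms, although nothing measured here explains why the step is this large.

From the compounds shown here alone, what remains open is how the step divides between the nitrogen and the change from an aromatic to a non-aromatic ring, a question that cyclohexyl at this carbon, a non-aromatic ring of carbon only, would help to settle. Also open, going by these compounds, is how the number would respond to an open-chain amine or a carboxylic acid at the same place.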